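Nitrophenyl in Place of Difluorophenyl: Expected Tolerability

The compounds below may be only part of what the source reports. "The series", "measured", "known", "first", "only" and "open" are said of these compounds alone.

Compound 1: `Cc1ccccc1-c1nn(-c2cc(F)ccc2F)cc1CNCCN1CCN(C)CC1` — > 20000 nM
Compound 2: `CN1CCN(CCNCc2cn(-c3ccc(F)cc3F)nc2-c2cccc(Cl)c2)CC1` — 15000 nM

Two compounds were measured in an ADME assay on Huh-7 cells (Homo sapiens) for cytotoxicity; a lower number here means that less compound is tolerated, a higher number that more compound is tolerated. For compound 1 the value > 20000 nM is a limit of the assay and not a number. Compound 1 thus stands only at a bound, namely (the limit of > 20000 nM in this assay, at which 1 of the 2 values shown sits). In this assay compound 2 gives 15000 nM.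

Compound 3, `Cc1ccccc1-c1nn(-c2ccc([N+](=O)[O-])cc2)cc1CNCCN1CCN(C)CC1`, has not yet been measured in this assay. It differs from compound 1 in one place: 4-nitrophenyl in place of 2,5-difluorophenyl on an aromatic nitrogen. Among the measured compounds shown here, no step between measured compounds that differ in only one place is available, so the size of this step can only be estimated. The expectation is a step of a number no higher from compound 1 to compound 3 (the limit leaves the size open), that is none beyond the usual scatter of this assay, with a fair chance that the result again sits at the limit. Compound 3 is therefore expected to give about 20000 nM, estimated to fall from 8000 nM to 40000 nM.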

Compound 3, half-maximal cytotoxic concentration: > 20000 nM
Compound 3: no number, only a limit; the forecaster's own chance of this, stated with the estimate: 55%; the middle value sits exactly at the limit.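

In this assay compound 3 gives > 20000 nM, a limit of the assay and not a number. Among the compounds shown here, compound 1 also stands at a limit, and no step between compound 1 and compound 3 can be read. The compounds shown leave open whether 4-nitrophenyl in place of 2,5-difluorophenyl on an aromatic nitrogen alters tolerance at all.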